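Trading a methoxy for a hydroxy: what to expect

The source may report more compounds than this note shows. Statements on the series, on what has been measured and on what is new or still open speak of the compounds shown alone.

Of the compounds shown here, three have been measured in a functional assay on SNB-75 cells (Homo sapiens) for cytotoxicity, read by sulforhodamine B assay, with a stated time of 48 h, tested at 0.001 uM; on this read-out lower numbers stand for a stronger effect and higher numbers for a weaker effect at the one concentration tested. Compound 1 `COc1cc(C)cc(-c2c(-c3ccnc(-c4ccc(C(C)=O)cc4)c3)cnn2CC#N)c1` gives 80%, compound 2 `Cc1cc(O)cc(-c2nn(CC#N)cc2-c2ccnc(-c3ccc(Oc4ccccc4)cc3)c2)c1` gives 86%, and compound 3 `COc1cc(C)cc(-c2nn(CC#N)cc2-c2ccnc(-c3ccc(N(C)C)cc3)c2)c1` gives 95%. Compound 3 stands highest of the three; compound 2 lies within the usual scatter of it, while compound 1 sits beyond the scatter below it. Compound 4 `Cc1cc(O)cc(-c2nn(CC#N)cc2-c2ccnc(-c3ccc(N(C)C)cc3)c2)c1` has not yet been measured. It differs from compound 3 in one place: hydrogen in place of methyl on an oxygen on an aromatic ring. For the measured compounds named here, no pair of measured compounds shows this change alone, so its effect is unknown; compound 2 and compound 3 carry the two groups but also differ elsewhere. The step is therefore expected to stay within the scatter in this assay, a number 5 percentage points lower from compound 3 to compound 4 (within the scatter). Compound 4 is estimated at 90%, with a range from 76% to 102%.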

Compound 4, a percentage reported as activity, at one concentration (the size of the read-out at that concentration, not a potency): 83%
Estimate against measurement, compound 4: 7 percentage points above, and the stated range covers the measured number.
By their numbers in this assay, from the lowest: compounds 1, 4, 2 and 3 (each within the scatter of the next, the first and the last beyond it).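

Trading methoxy for hydroxy on the 3-methoxy-5-methylphenyl group gives a number 12 percentage points lower from compound 3 to compound 4 (beyond the scatter) in this assay and so this single change does move the read-out, modestly, in a compound carrying dimethylamino. With the hydroxy kept, dimethylamino in place of phenoxy gives a number 3 percentage points lower from compound 2 to compound 4 (within the scatter) so that swap shows no clear change here. Nothing available explains either result.

For the compounds shown here, only one pair shows the hydroxy step, so whether it holds alongside other groups stays open. An ethoxy, with a longer chain on that oxygen, or an amine in place of the hydroxy would test how much this position tolerates.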